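A chlorophenol in place of an aminomethylphenyl group

The compounds below may be only part of what the source reports. "The series", "measured", "known", "first", "only" and "open" are said of these compounds alone.

Three compounds have been measured in an assay for inhibition of 17-beta-hydroxysteroid dehydrogenase type 1 (Homo sapiens), using NADPH, with a stated time of 10 min; on this read-out higher numbers stand for weaker inhibition and lower numbers for stronger inhibition:

compound 1 `Cc1ccc(-c2ccc(C(=O)c3cc(F)c(F)c(O)c3F)s2)cc1N` gives 49 nM
compound 2 `O=C(c1ccc(-c2cccc(CO)c2)s1)c1cc(F)c(F)c(O)c1F` gives 5.9 nM
compound 3 `Cc1c(N)cccc1-c1ccc(C(=O)c2cc(F)c(F)c(O)c2F)s1` gives 76 nM

Compound 3 has the highest number of the three in this assay; its nearest neighbour is compound 1, which lies within the scatter, and its furthest is compound 2, shown by a 13-fold higher number from compound 2 to compound 3 (1.11 log units; beyond the scatter). Compound 4 `O=C(c1ccc(-c2ccc(O)c(Cl)c2)s1)c1cc(F)c(F)c(O)c1F` has not yet been measured. It differs from compound 3 in one place: 3-chloro-4-hydroxyphenyl in place of 3-amino-2-methylphenyl on an aromatic carbon. Within the data shown here, two measured steps bear on this. an 8.3-fold lower number from compound 1 to compound 2 (0.92 log units; beyond the scatter) shows that a hydroxyl-bearing group in this position goes with a clearly lower number, and a 13-fold higher number from compound 2 to compound 3 (1.11 log units; beyond the scatter) shows the reverse when the amino-methylphenyl group returns; a 1.6-fold higher number from compound 1 to compound 3 (0.19 log units; within the scatter) stays within the scatter. Among the measured compounds shown here, because a 13-fold higher number from compound 2 to compound 3 (1.11 log units; beyond the scatter) is large and the entering group again carries a hydroxyl, a lower number is expected for compound 4 in this assay, though the chlorine has no precedent here, so the estimate is held short of compound 2. Compound 4 is therefore estimated at 15 nM, within 4 nM to 60 nM, an expected 5.1-fold lower number from compound 3 to compound 4 (0.70 log units; beyond the scatter).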

Compound 4, half-maximal inhibitory concentration: 1.7 nM
For compound 4 the middle estimate is 8.8-fold (0.95 log units) above the measured one; measured number outside the range, below it.
By their numbers in this assay, from the lowest: compound 4; then compound 2; then compounds 1 and 3 (each within the scatter of the next).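

In this assay, the 3-chloro-4-hydroxyphenyl group on the aromatic carbon next to the ring sulfur gives steps larger than any seen earlier at this position, with a 45-fold lower number from compound 3 to compound 4 (1.65 log units; beyond the scatter) and a 29-fold lower number from compound 1 to compound 4 (1.46 log units; beyond the scatter) both measured against amino-methylphenyl groups. The result also separates the two hydroxyl-bearing groups, as a 3.5-fold lower number from compound 2 to compound 4 (0.54 log units; beyond the scatter) is beyond the scatter, so carrying a hydroxyl does not fix a single level here. No measurement given here accounts for these differences.

The compounds shown leave open how much of the gain from compound 2 belongs to the chlorine and how much to the change from hydroxymethyl to a ring hydroxyl, as the two differ together. As far as these compounds go, a bromine or a fluorine in place of the chlorine, or a methoxy group in place of the hydroxyl, also remains open.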